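Anilino to methylamino on the shared core

The source may report more compounds than this note shows. Statements on the series, on what has been measured and on what is new or still open speak of the compounds shown alone.

compound 1 `N#Cc1c(Cl)nc(SCc2nc3ccccc3[nH]2)nc1-c1ccccc1` gives 11.3 nM
compound 2 `N#Cc1c(NN)nc(SCc2nc3ccccc3[nH]2)nc1-c1ccccc1` gives 14.7 nM
compound 3 `N#Cc1c(Nc2ccccc2)nc(SCc2nc3ccccc3[nH]2)nc1-c1ccccc1` gives 3.2 nM

The values come from a functional assay on K562 cells (Homo sapiens) for cytotoxicity, read by MTT assay, with a stated time of 3 days (on this read-out lower numbers stand for stronger inhibition and higher numbers for weaker inhibition), and compound 3 has the lowest of the three. Both steps into it lie beyond the scatter (a 3.5-fold lower number from compound 1 to compound 3 (0.55 log units; beyond the scatter) and a 4.6-fold lower number from compound 2 to compound 3 (0.66 log units; beyond the scatter)), whereas the step between the other two stays within it (a 1.3-fold higher number from compound 1 to compound 2 (0.11 log units; within the scatter)). Next is compound 4 `CNc1nc(SCc2nc3ccccc3[nH]2)nc(-c2ccccc2)c1C#N` with methyl in place of phenyl on a nitrogen on an aromatic ring. For the measured compounds named here, no measured compound carries methyl on that nitrogen. Going by the values given here, the nearest precedent is the change at that same nitrogen (a 4.6-fold lower number from compound 2 to compound 3 (0.66 log units; beyond the scatter)), a modest step that is read in reverse here, since phenyl leaves. The step from chloro is also modest and points the same way. A modest move to a higher number is therefore expected (a 3.1-fold higher number from compound 3 to compound 4 (0.49 log units; beyond the scatter)), beyond the scatter but not certainly so. For compound 4 the estimated value is 10 nM (expected range 3.5 nM to 30 nM).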

Compound 4, half-maximal inhibitory concentration: 13.2 nM
For compound 4 the middle estimate is 1.3-fold (0.12 log units) below the measured one; the range from low to high includes it.
By their numbers in this assay, from the lowest: compound 3; then compounds 1, 4 and 2 (each within the scatter of the next).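

In this series, the phenyl on the nitrogen on the aromatic ring cannot be exchanged for methyl without a move to a higher number in this assay (a 4.1-fold higher number from compound 3 to compound 4 (0.62 log units; beyond the scatter)). Methylamino reads level with the amino on that nitrogen (a 1.1-fold lower number from compound 2 to compound 4 (0.05 log units; within the scatter)) and with chloro on the aromatic carbon (a 1.2-fold higher number from compound 1 to compound 4 (0.07 log units; within the scatter)), so among the four compounds only the anilino group stands apart, while a small methyl gives no gain over either of the other two. No measurement here accounts for the anilino advantage.

Still open, going by these compounds, is whether a benzyl or cyclohexyl group on that nitrogen would keep the lower number of the anilino compound. On these data alone, it is also open whether dimethylamino or morpholine in place of chloro would read level with methylamino.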